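Chromene carboxamide series: ester to primary amide at carbonyl

The compounds below may be only part of what the source reports. "The series", "measured", "known", "first", "only" and "open" are said of these compounds alone.

Measured so far in a functional assay for inhibition of nuclear factor NF-kappa-B complex (Homo sapiens); on this read-out lower numbers stand for stronger inhibition and higher numbers for weaker inhibition:
Compound 1, `COc1ccc2c(c1)OC(c1cc(OC)c(OC)c(OC)c1)C(C(=O)NC(C)(C)C)=C2`, gives 28400 nM.
Compound 2, `CCOC(=O)C1=Cc2ccc(OC)cc2OC1c1cc(OC)c(OC)c(OC)c1`, gives 25000 nM.

Among the compounds with values here, compound 2 has the lowest of the two numbers, and its nearest neighbour is compound 1; the single step that connects them, a 1.1-fold lower number from compound 1 to compound 2 (0.06 log units; within the scatter), does not rise above the scatter, so the two compounds cannot be ordered against each other on this read-out.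

Compound 3, `COc1ccc2c(c1)OC(c1cc(OC)c(OC)c(OC)c1)C(C(N)=O)=C2`, remains unmeasured. It differs from compound 2 in one place: amino in place of ethoxy on a carbonyl carbon.

Within the data shown here, only one step bears on this change, the exchange at the same carbonyl carbon recorded as a 1.1-fold lower number from compound 1 to compound 2 (0.06 log units; within the scatter), and that step is within the scatter. Nothing in the two measured compounds shows that the group on this carbonyl carbon moves the number in either direction. A step no larger than the scatter is therefore expected from compound 2 to compound 3, a 1.0-fold higher number from compound 2 to compound 3 (0.02 log units; within the scatter), and compound 3 is estimated at 26000 nM in this assay, with a range from 11000 nM to 60000 nM.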

Compound 3, half-maximal inhibitory concentration: > 50000 nM
Compound 3: a limit, no number; the forecaster's own chance of this, stated with the estimate: 15%; middle value at least 1.9-fold (0.28 log units) away from the limit.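

Compound 3 gives > 50000 nM in this assay as a limit of the assay and not a number. The two steps into compound 3 are floors only, an at least 2.0-fold higher number from compound 2 to compound 3 (0.30 log units; that floor lies within the scatter) for the exchange of ethoxy for amino on the carbonyl carbon and an at least 1.7-fold higher number from compound 1 to compound 3 (0.24 log units; that floor lies within the scatter) for the exchange of tert-butyl for hydrogen on the amide-type nitrogen, so neither fixes the true size of the change, and no order among the three compounds can be claimed from them. The new information is that carbamoyl at this position gives the first result in the series without a number on this read-out, whereas compound 1 and compound 2 both gave one, so the step between those two cannot be taken to hold for every group on this carbonyl carbon: the limit of > 50000 nM in this assay, at which 1 of the 3 values shown sits.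

On these data alone, whether a carboxylic acid or a methylamino group on this carbonyl carbon would give a number within the range of the assay remains open. As far as these compounds go, it is also open whether a methyl, ethyl or isopropyl group on the amide-type nitrogen would stay close to compound 1 or fall at the limit with compound 3.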